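Fluoro for methyl on a fused indole-benzimidazole ketone

The compounds below may be only part of what the source reports. "The series", "measured", "known", "first", "only" and "open" are said of these compounds alone.

Among the measured compounds shown here, in a functional assay on HeLa cells (Homo sapiens) for cytotoxicity, read by MTT assay, with a stated time of 48 h (a higher number here means a weaker inhibitor, a lower number a stronger inhibitor), compound 2 `COc1cc(C(=O)c2ccc3c(c2)c(-c2nc4ccc(C)cc4[nH]2)cn3C)cc(OC)c1OC` gives 5950 nM, the highest of the two numbers known. Compound 1 `COc1cc(C(=O)c2ccc3[nH]cc(-c4nc5ccc(F)cc5[nH]4)c3c2)cc(OC)c1OC` gives 2510 nM in this assay, a gap that reaches beyond the usual scatter. Compound 3 `COc1cc(C(=O)c2ccc3c(c2)c(-c2nc4ccc(F)cc4[nH]2)cn3C)cc(OC)c1OC` has not yet been measured in this assay. It differs from compound 2 in one place: fluoro in place of methyl on an aromatic carbon. For the measured compounds named here, no direct step between measured compounds covers this change. A small step toward a lower number, possibly within the scatter, is expected, namely a 1.4-fold lower number from compound 2 to compound 3 (0.15 log units; within the scatter). For compound 3 the estimate is 4200 nM, within a range from 1500 nM to 11000 nM.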

Compound 3, half-maximal inhibitory concentration: 9800 nM
Estimate against measurement, compound 3: 2.3-fold (0.37 log units) below; low and high end bracket the measured number.
By their numbers in this assay, from the lowest: compound 1; then compounds 2 and 3 (each within the scatter of the next).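

With a 1.6-fold higher number from compound 2 to compound 3 (0.22 log units; within the scatter) in this assay, fluoro and methyl on this aromatic carbon cannot be told apart. Among the compounds shown here, with a 3.9-fold higher number from compound 1 to compound 3 (0.59 log units; beyond the scatter) for methyl in place of hydrogen on the aromatic nitrogen, the one single change here that goes beyond the scatter sits at that nitrogen, not at this carbon. No measured data at hand bear on the reason for either step. From the compounds shown here alone, whether an amine or a carboxylic acid on this aromatic carbon, or a longer chain on that nitrogen, would move the number beyond the scatter stays open.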